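Removing the methoxy group from compound 2

The source may hold more compounds than are shown below. What is called first, only, known or untested is meant among the compounds shown, and "the series" means these compounds.

Three compounds share one core and differ only in one group on an aromatic carbon. Compound 1 `COc1ccccc1-n1c(Nc2nc(-c3ccc([N+](=O)[O-])cc3)cs2)n[nH]c1=S`, compound 2 `COc1ccccc1-n1c(Nc2nc(-c3ccccc3)cs2)n[nH]c1=S` and compound 3 `COc1ccccc1-n1c(Nc2nc(-c3ccc(Cl)cc3)cs2)n[nH]c1=S` were run in a functional assay on the whole organism (strain Swiss albino) for inhibition, with Mus musculus as the target, with a stated time of 0.5 h; a higher number here means that more compound is needed for the effect, a lower number that less compound is needed; compound 1 gives 100 mg/kg, compound 2 gives 100 mg/kg and compound 3 gives 100 mg/kg. Compound 2 stands level with both: no change at the digits printed from compound 1 to compound 2 (within the scatter), no change at the digits printed from compound 1 to compound 3 (within the scatter) and no change at the digits printed from compound 2 to compound 3 (within the scatter). Compound 4 `S=c1[nH]nc(Nc2nc(-c3ccccc3)cs2)n1-c1ccccc1` is not yet measured; it differs from compound 2 by hydrogen in place of methoxy on an aromatic carbon. Among the measured compounds shown here, no measured step touches that part of the molecule, and the three steps on the other ring all left the dose unchanged. The expected step of no change at the digits printed from compound 2 to compound 4 (within the scatter) is therefore none beyond the scatter. Compound 4 is estimated at 100 mg/kg, with a range from 50 mg/kg to 200 mg/kg.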

Compound 4, minimum effective dose: 300 mg/kg
Estimate against measurement, compound 4: 3.0-fold (0.48 log units) below; measured number above the stated range.
By their numbers in this assay, from the lowest: compounds 1, 2 and 3 (each within the scatter of the next); then compound 4.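

In this assay, going from 2-methoxyphenyl to phenyl gives a 3.0-fold higher number from compound 2 to compound 4 (0.48 log units; beyond the scatter). Among the compounds shown here, this is the first step beyond the scatter, so the dose responds to a change at this place, unlike the three steps on the other ring. No data at hand explain the step.

The compounds shown compare only methoxy and hydrogen here, leaving open whether a methyl, an ethoxy or an amine at this place would match methoxy. Also open, going by these compounds, is whether the step holds with chloro or nitro on the other ring.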